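The source may hold more compounds than are shown below. What is called first, only, known or untested is meant among the compounds shown, and "the series" means these compounds.

Measured compounds:
compound 1 `Nc1cccc(CNc2cc(C(F)(F)F)cc3[nH]ncc23)c1`, 68%
compound 2 `O=[N+]([O-])c1cccc(CNc2cc(C(F)(F)F)cc3[nH]ncc23)c1`, 60%
compound 3 `CNC(=O)c1cccc(CNc2cc(C(F)(F)F)cc3[nH]ncc23)c1`, 71%

In an assay for inhibition of Tryptophan 2,3-dioxygenase (Homo sapiens), with stated times of 10 min and 60 min, tested at 10 uM (a higher number here means a stronger effect of the compound at the concentration tested, a lower number a weaker effect), compound 3 stands highest of the three numbers, though its gap to compound 1 is within the scatter; only compound 2 lies beyond it. The unmeasured compound 4 `FC(F)(F)c1cccc(CNc2cc(C(F)(F)F)cc3[nH]ncc23)c1` differs from compound 3 by trifluoromethyl in place of methylcarbamoyl on an aromatic carbon. For the measured compounds named here, the steps that bear on this exchange at the same aromatic carbon are a number 3 percentage points higher from compound 1 to compound 3 (within the scatter), a number 11 percentage points higher from compound 2 to compound 3 (beyond the scatter) and a number 8 percentage points lower from compound 1 to compound 2 (within the scatter): three different groups at that place give numbers in a narrow band. A fourth group there is therefore expected to stay near that band, with no step beyond the scatter or at most a modest one downward. Compound 4 is expected to give 62%, between 45% and 78%. The expected step in this assay is a number 9 percentage points lower from compound 3 to compound 4 (within the scatter).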

Compound 4, a percentage reported as inhibition, at one concentration (the size of the read-out at that concentration, not a potency): 40%
Estimate against measurement, compound 4: 22 percentage points above, and the stated range ends above it.
By their numbers in this assay, from the lowest: compound 4; then compounds 2, 1 and 3 (each within the scatter of the next, the first and the last beyond it).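

Working from this assay, the aromatic carbon carrying these groups is less tolerant than the three earlier groups suggested: trifluoromethyl gives a number 31 percentage points lower from compound 3 to compound 4 (beyond the scatter), a number 20 percentage points lower from compound 2 to compound 4 (beyond the scatter) and a number 28 percentage points lower from compound 1 to compound 4 (beyond the scatter). The narrow band of amino, nitro and methylcarbamoyl therefore does not extend to every group at this place. The change from methylcarbamoyl also removes the hydrogen-bond donor and acceptor counted on that group, but no measurement here connects this difference with the drop.

As far as these compounds go, it remains open whether a methyl, a chlorine or a nitrile at this carbon would fall with trifluoromethyl or stay with the other three groups.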